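This account rests on a few compounds, and the source may have more. Where it says the series, first, only, none or still open, it means among the compounds named here.

Measured in an ADME assay on HepG2 cells (Homo sapiens) for cytotoxicity, read by neutral red uptake, with a stated time of 24 h; on this read-out lower numbers stand for stronger inhibition and higher numbers for weaker inhibition:
- Compound 1 `CC(=O)Oc1c(C(C)C)cc2c3c1OC(=O)[C@@]31CCCC(C)(C)[C@@H]1CC2`: 294000 nM
- Compound 2 `CC(C)c1cc2c3c(c1OC(=O)Cc1c[nH]c4ccccc14)OC(=O)[C@@]31CCCC(C)(C)[C@@H]1CC2`: 251000 nM

Among the measured compounds shown here, compound 2 stands within the scatter of compound 1, the only other compound measured, so the two cannot be ranked. Compound 3 `CC(C)c1cc2c3c(c1OC(=O)CCCc1c[nH]c4ccccc14)OC(=O)[C@@]31CCCC(C)(C)[C@@H]1CC2` differs from compound 2 in one place: 2-(1H-indol-3-yl)ethyl in place of 1H-indol-3-yl on a saturated chain carbon bound to a carbonyl carbon. In words, this is 2-(1H-indol-3-yl)ethyl in place of 1H-indol-3-yl on a saturated chain carbon bound to a carbonyl carbon. For the measured compounds named here, one measured step bears on this change: a 1.2-fold lower number from compound 1 to compound 2 (0.07 log units; within the scatter), with 1H-indol-3-yl in place of hydrogen on such a carbon. That step stayed within the scatter, so no step beyond the scatter is expected in this assay here. Going by the values given here, no measured pair shows a longer chain, which leaves this expectation resting on a single comparison. The expected step is a 1.1-fold lower number from compound 2 to compound 3 (0.04 log units; within the scatter). Compound 3 is estimated at 230000 nM, with an expected range of 110000 nM to 420000 nM.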

Compound 3, half-maximal inhibitory concentration: 120000 nM
For compound 3 the middle estimate is 1.9-fold (0.28 log units) above the measured one, within the range that was stated.
By their numbers in this assay, from the lowest: compound 3; then compounds 2 and 1 (each within the scatter of the next).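

In this assay the change to 2-(1H-indol-3-yl)ethyl in place of 1H-indol-3-yl on a saturated chain carbon bound to a carbonyl carbon gives a 2.1-fold lower number from compound 2 to compound 3 (0.32 log units; beyond the scatter) and so passes the scatter, if only modestly. Set against hydrogen at the same place, this longer group gives a 2.5-fold lower number from compound 1 to compound 3 (0.39 log units; beyond the scatter) while 1H-indol-3-yl alone gave no readable change, so among these three compounds the number at this position moves only once the chain is longer. No evidence is at hand on what lies behind this shift. The compounds shown leave open whether a still longer chain would carry the number further in the same direction. They also leave open whether the chain alone matters, or whether an amine or a carboxylic acid at its end in place of the 1H-indol-3-yl would give the same step.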